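The source may report more compounds than this note shows. Statements on the series, on what has been measured and on what is new or still open speak of the compounds shown alone.

Measured so far in a functional assay on RAW264.7 cells (Mus musculus) for inhibition; on this read-out lower numbers stand for stronger inhibition and higher numbers for weaker inhibition:
Compound 1 `O=C1/C(=C/c2cccc(Cl)c2)CCc2cc(O)ccc21` gives 1750 nM
Compound 2 `O=C1/C(=C/c2ccccc2)CCc2ccc(O)cc21` gives 710 nM
Compound 3 `O=C1/C(=C/c2ccc(F)cc2)CCc2ccc(O)cc21` gives 840 nM

Compound 3 stands second highest of the three numbers in this assay. Its nearest neighbour is compound 2, and the step of a 1.2-fold higher number from compound 2 to compound 3 (0.07 log units; within the scatter) is within the scatter, so the two cannot be ordered. Compound 1 is the furthest away; compound 1 gives 1750 nM while compound 3 gives 840 nM, a gap beyond the scatter.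

Compound 4 `O=C1/C(=C/c2ccc(C(F)(F)F)cc2)CCc2ccc(O)cc21` is not yet measured. It differs from compound 3 as follows: trifluoromethyl in place of fluoro on an aromatic carbon. Among the compounds with values here, the only measured step that bears on the same position is a 1.2-fold higher number from compound 2 to compound 3 (0.07 log units; within the scatter), which was within the scatter; no measured step shows a trifluoromethyl at any position, so the data give no guide beyond that. A small step is therefore expected, in either direction, most likely none beyond the scatter. Compound 4 is estimated at 1000 nM, with a range from 400 nM to 2500 nM. The expected step of a 1.2-fold higher number from compound 3 to compound 4 (0.08 log units; within the scatter) is thus close to nil.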

Compound 4, half-maximal inhibitory concentration: > 10000 nM
Compound 4 gave a limit, no number (the forecaster's own chance of this, stated with the estimate: 5%); at least 10-fold (1.00 log units) between middle value and limit.
By their numbers in this assay, from the lowest: compounds 2 and 3 (each within the scatter of the next); then compound 1. At a limit, above all of these: compound 4.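

In this assay compound 4 gives > 10000 nM, which is a limit of the assay and not a number. On this aromatic carbon, para to a large group, fluoro in place of hydrogen gave only a 1.2-fold higher number from compound 2 to compound 3 (0.07 log units; within the scatter), whereas trifluoromethyl gives an at least 11-fold higher number from compound 3 to compound 4 (1.07 log units; beyond the scatter), and against hydrogen it gives an at least 14-fold higher number from compound 2 to compound 4 (1.14 log units; beyond the scatter). The position is therefore not indifferent to what it carries, and the full size of the loss stays unresolved: the limit of > 10000 nM in this assay, at which 1 of the 4 values shown sits.

The compounds shown do not tell whether this loss belongs to trifluoromethyl alone or would also appear with methyl, methoxy or an amine on the same carbon. Compound 1 differs from the others in more than one place, so it gives no reading on this position.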